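Chloro in Place of Methyl on the Anilide Ring

The source may report more compounds than this note shows. Statements on the series, on what has been measured and on what is new or still open speak of the compounds shown alone.

Measured compounds:
compound 1, `CCNC(=O)c1cc(-c2ccc(F)cc2F)ccc1OC(C)=O`: 5.38%
compound 2, `CC(=O)Oc1ccc(-c2ccc(F)cc2F)cc1C(=O)Nc1ccccc1C`: 19.6%

In a functional assay on the whole organism (Ear) for inhibition, with Mus musculus as the target, at a dose of 40 mg/kg by the oral route (on this read-out lower numbers stand for less inhibition and higher numbers for more inhibition at the one dose given (going by the name of the read-out)), compound 2 gives 19.6%, the higher of the two numbers. Compound 1 gives 5.38%. Among the measured compounds shown here, the only measured step, a number 14.2 percentage points higher from compound 1 to compound 2 (beyond the scatter), concerns the group on the amide nitrogen and nothing on the aromatic ring itself.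

Compound 3, `CC(=O)Oc1ccc(-c2ccc(F)cc2F)cc1C(=O)Nc1ccccc1Cl`, differs from compound 2 by chloro in place of methyl on an aromatic carbon. For the measured compounds named here, no measured pair shows a change of a substituent on that ring, so the one known step offers no direct guide to this exchange, and the data give no reason to expect a move in either direction. The writer therefore expects a step of a number 0.4 percentage points higher from compound 2 to compound 3 (within the scatter), not beyond the scatter. Compound 3 is estimated at 20% in this assay, with a range from 5% to 40%.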

Compound 3, a percentage reported as inhibition, in the whole organism at one dose (the size of the read-out at that dose, not a potency): 41.4%
Beside the measured number, compound 3's estimate is 21.4 percentage points below it; the measured number lies above the stated range.
By their numbers in this assay, from the lowest: compound 1; then compound 2; then compound 3.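

Among the compounds shown here, the exchange of methyl for chloro on an aromatic carbon, ortho to a large group, is the first measured change on this ring, and in this assay it gives a number 21.8 percentage points higher from compound 2 to compound 3 (beyond the scatter). One heavy atom for one heavy atom is thus enough to move the read-out at this place, which the change on the amide nitrogen alone could not show. Against the ethyl amide, the 2-chlorophenyl group gives a number 36 percentage points higher from compound 1 to compound 3 (beyond the scatter), and nothing measured here accounts for the rise.

Going by these compounds, whether the gain is particular to chloro stays open: fluoro, bromo, methoxy or trifluoromethyl at this place would test that. Also open, on these data alone, is how the series would read with a free hydroxyl in place of the acetate on the shared core.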